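The source may report more compounds than this note shows. Statements on the series, on what has been measured and on what is new or still open speak of the compounds shown alone.

Measured compounds:

Compound 1, `C/C(=C\c1cc(-c2ccc(C)nc2)co1)C(N)=O`. In an ADME assay on NIH3T3 cells (Mus musculus) for cytotoxicity, read by CCK-8 assay, with a stated time of 24 h (a lower number here means a stronger inhibitor, a higher number a weaker inhibitor), compound 1 gives > 50000 nM, a limit of the assay rather than a number.

Compound 2, `C/C(=C\c1cc(-c2ccc(F)nc2)co1)C(N)=O`. In this assay compound 2 gives > 50000 nM, again a limit.

Compound 3, `C/C(=C\c1ccc(-c2ccc(C)cc2)o1)C(N)=O`. In this assay compound 3 gives > 50000 nM, also a limit.

Compound 1 and compound 2 differ by fluoro in place of methyl on an aromatic carbon. Because both values sit at the limit of > 50000 nM in this assay, at which 3 of the 3 values shown sit, this gives a step that the two limits leave unreadable from compound 1 to compound 2. Compound 4, `C/C(=C\c1ccc(-c2ccc(F)cc2)o1)C(N)=O`, is not yet measured; it differs from compound 3 by fluoro in place of methyl on an aromatic carbon. This is the same kind of change as that from compound 1 to compound 2, but the surroundings differ: there the ring was a six-membered aromatic ring with 1 nitrogen, next to the ring nitrogen, here it is a six-membered aromatic ring of carbon only. How the core of compound 1 and the core of compound 3 differ is not broken down here.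

Since compound 3 sits at the limit of > 50000 nM in this assay, at which 3 of the 3 values shown sit, and the earlier change gave a step that the two limits leave unreadable from compound 1 to compound 2, the expected step is a step that the limit leaves unreadable from compound 3 to compound 4, and compound 4 is estimated at 80000 nM, most likely again only a limit, between 40000 nM and 200000 nM.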

Compound 4, half-maximal inhibitory concentration: 960 nM
Compound 4: the middle estimate sits 83-fold (1.92 log units) above what was measured; the measured number lies below the stated range.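

In this assay, fluoro in place of methyl on an aromatic carbon of the six-membered ring of carbon only gives an at least 52-fold lower number from compound 3 to compound 4 (1.71 log units; beyond the scatter), so on the core of compound 3 this one small swap has a large effect. The same swap on the core of compound 1 gives a step that cannot be read, because both of its values are limits of the assay and not numbers: the limit of > 50000 nM in this assay, at which 3 of the 4 values shown sit. The result therefore shows that the change can matter on one core, but not that its effect carries over to another, since the pair on the core of compound 1 could hide a large step, a small one or none.

The compounds shown leave open whether this effect is specific to fluoro, since a chloro group, a methoxy group or a plain hydrogen at that place could show how other groups compare with methyl. They also leave open how a carboxylic acid in place of the amide would behave on either core.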